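Reversed Ester Linker and an Aryl Swap on the Furan Carbon

A few compounds are considered here, and "the series" means these few. Any claim that something is new, unique, unknown or untested is made for them only; others in the source may bear on it.

Of the compounds shown here, three have been measured in an assay on isolated protein for inhibition of high affinity 3',5'-cyclic-AMP phosphodiesterase 7A (Homo sapiens), read by scintillation proximity assay and cAMP accumulation, with a stated time of 20 min, tested at 10 uM; a lower number here means less inhibition, a higher number more inhibition at the concentration tested (going by the name of the read-out). Compound 1 `CCOc1cc(C(=O)OCc2ccc(-c3ccc(Cl)cc3Cl)o2)cc(OCC)c1OCC` gives 3.7%. Compound 2 `CCOc1cc(C(=O)OCc2ccc(-c3ccc(C)cc3)o2)cc(OCC)c1OCC` gives 16.4%. Compound 3 `CCOc1cc(COC(=O)c2ccc(-c3ccc(Cl)cc3Cl)o2)cc(OCC)c1OCC` gives 31.1%, the highest of the three numbers, with compound 2 the nearest and compound 1 the furthest below it; both gaps are beyond the usual scatter.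

Compound 1 and compound 2 share a core and differ in one place: 4-methylphenyl in place of 2,4-dichlorophenyl on an aromatic carbon. This change gave a number 12.7 percentage points higher from compound 1 to compound 2 (beyond the scatter), a modest step beyond the scatter.

Among the compounds with values here, compound 3 has the same atoms as compound 1, joined differently; the difference between the two cores is not broken down here, and no step is given for that pair beyond what the two values show.

Compound 4 `CCOc1cc(COC(=O)c2ccc(-c3ccc(C)cc3)o2)cc(OCC)c1OCC` is not yet measured. It stands to compound 3 as compound 2 stands to compound 1: 4-methylphenyl in place of 2,4-dichlorophenyl on an aromatic carbon. The place is the same word for word in both pairs, so the change is the same.

On the core of compound 3, the same change is expected to give a step of similar size, a number 11.9 percentage points higher from compound 3 to compound 4 (beyond the scatter), because on the core of compound 1 it gave a number 12.7 percentage points higher from compound 1 to compound 2 (beyond the scatter). That expectation rests on a single measured pair. For compound 4, the estimate in this assay is 43%, expected to fall between 24% and 62%.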

Compound 4, a percentage reported as inhibition, at one concentration (the size of the read-out at that concentration, not a potency): 28%
The estimate for compound 4 lay 15 percentage points above the measured number, within the range that was stated.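

In this assay, putting 4-methylphenyl in place of 2,4-dichlorophenyl on the core of compound 3 gave a number 3.1 percentage points lower from compound 3 to compound 4 (within the scatter), so on this core the two aryl groups cannot be told apart. The change therefore did not carry over from one core to the other with the size it had on the first, and the step seen on the core of compound 1 would not have served as a guide to the step on the core of compound 3: the same change on two cores in this assay, a number 12.7 percentage points higher (beyond the scatter) from compound 1 to compound 2 and a number 3.1 percentage points lower (within the scatter) from compound 3 to compound 4, 15.8 percentage points apart, beyond the scatter of two such steps This shows that, in this small series, the outcome of the swap depends on the core that carries it, but it does not show why, and with one pair on each core it offers no rule for predicting the swap on any further core.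

The compounds shown cover only these two aryl groups and these two arrangements of the ester linker, each read at a single concentration, so how either core would respond to an aryl group bearing an amine or a carboxylic acid remains open. Also open, from the compounds shown here alone, is whether an amide linker in place of the ester would follow the core of compound 1, the core of compound 3, or neither.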